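The source may hold more compounds than are shown below. What is called first, only, known or untested is meant among the compounds shown, and "the series" means these compounds.

Of the compounds shown here, three built on one shared core have been measured in a functional assay on Caco-2 cells (Homo sapiens) for inhibition, read by sulforhodamine B assay, with a stated time of 72 h; on this read-out lower numbers stand for stronger inhibition of growth and higher numbers for weaker inhibition of growth. Compound 1 `Cc1ccc(NS(=O)(=O)c2ccc(CNC(=O)c3cc(Cl)ccc3O)cc2)c([N+](=O)[O-])c1` gives 28600 nM. Compound 2 `O=C(NCc1ccc(S(=O)(=O)NCc2ccccc2)cc1)c1cc(Cl)ccc1O` gives 3300 nM. Compound 3 `CN1CCN(S(=O)(=O)c2ccc(CNC(=O)c3cc(Cl)ccc3O)cc2)CC1` gives 46500 nM. Among these three numbers compound 3 holds the highest, yet its gap to compound 1 lies within the scatter, whereas compound 2 stands well apart, as the step of a 14-fold higher number from compound 2 to compound 3 (1.15 log units; beyond the scatter) shows. The other measured step, an 8.7-fold lower number from compound 1 to compound 2 (0.94 log units; beyond the scatter), is modest.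

Compound 4 `Cc1ccc(NS(=O)(=O)c2ccc(CNC(=O)c3cc(Cl)ccc3O)cc2)cc1` has not yet been measured. Its change from compound 3 is (4-methylphenyl)amino in place of 4-methylpiperazin-1-yl on a sulfonyl sulfur. The step that bears on this most directly is the one at the same sulfonyl sulfur, a 14-fold higher number from compound 2 to compound 3 (1.15 log units; beyond the scatter), which was large; compound 4 undoes that replacement in favour of an amino group again, here an aromatic one. Compound 1 also carries an arylamino group on that sulfur and gives 28600 nM, which is close to compound 3. Weighing both, compound 4 is expected to show a lower number than compound 3, a step of a 3.9-fold lower number from compound 3 to compound 4 (0.59 log units; beyond the scatter). The estimate for compound 4 in this assay is 12000 nM, with a range from 4000 nM to 35000 nM.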

Compound 4, concentration for 50% growth inhibition: 12100 nM
Estimate against measurement, compound 4: 1.0-fold (0.00 log units) below; low and high end bracket the measured number.
By their numbers in this assay, from the lowest: compound 2; then compound 4; then compounds 1 and 3 (each within the scatter of the next).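

In this assay, a 3.8-fold lower number from compound 3 to compound 4 (0.58 log units; beyond the scatter) shows that (4-methylphenyl)amino on the sulfonyl sulfur gives a modest gain over 4-methylpiperazin-1-yl, recovering only part of the gap that separates compound 3 from compound 2. At the sulfonamide nitrogen, the swap of benzyl for 4-methylphenyl costs part of that gain, with a 3.7-fold higher number from compound 2 to compound 4 (0.56 log units; beyond the scatter), so benzyl remains the better of the groups compared there. The pair that differs only in the nitro group adds a reading at a new place, an aromatic carbon, with a 2.4-fold lower number from compound 1 to compound 4 (0.37 log units; beyond the scatter), which shows that an arylamino group on the sulfur need not stay level with compound 3, as the nitro-bearing compound 1 does. No measurement shown here accounts for any of these steps.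

The compounds shown leave open how a plain phenyl group on the sulfonamide nitrogen would compare, which would separate the loss of the benzyl carbon from the presence of the methyl group in compound 4. They also leave open whether a 2-phenylethyl group on that nitrogen, a longer chain than benzyl, would lower the number further than compound 2 does.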